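Working notes: chain-end variation, compound 3 to compound 4

The compounds below may be only part of what the source reports. "The series", "measured", "known", "first", "only" and "open" are said of these compounds alone.

- compound 1 `COCCCCCCCCCCCCCCC/C=C1/CC(CO)(COC(=O)C(C)(C)C)OC1=O`: 1.64 ug/mL
- compound 2 `COC(=O)CCCCCCCCCCCCCC/C=C1\CC(CO)(COC(=O)C(C)(C)C)OC1=O`: > 10 ug/mL
- compound 3 `CCCCCCCCC(O)CCCCCC/C=C1\CC(CO)(COC(=O)C(C)(C)C)OC1=O`: 7.91 ug/mL

In a functional assay on MOLT-4F cells (Homo sapiens) for antiproliferative activity (a higher number here means a weaker inhibitor of growth, a lower number a stronger inhibitor of growth), compound 3 gives the higher of the two actual numbers (7.91 ug/mL), and compound 1 gives the lower (1.64 ug/mL). The gap between these two numbers lies beyond the scatter. Compound 2 gives only a limit of the assay (> 10 ug/mL).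

Compound 4 `CC(C)(C)C(=O)OCC1(CO)C/C(=C\CCCCCCCCCCCCCCC=O)C(=O)O1` has 8-formyloctyl in place of 1-hydroxynonyl on a saturated chain carbon, six bonds along the chain from a double-bonded chain carbon. Among the compounds with values here, no measured step covers this change, so the expectation stays close to compound 3 (7.91 ug/mL). The expected step of a 1.3-fold lower number from compound 3 to compound 4 (0.12 log units; within the scatter) lies within the scatter, with no direction expected in this assay. For compound 4 the estimated value is 6 ug/mL (expected range 2 ug/mL to 14 ug/mL).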

Compound 4, concentration for 50% growth inhibition: > 10 ug/mL
Compound 4: only a limit was reported; the forecaster's own chance of this, stated with the estimate: 25%; middle value at least 1.6-fold (0.22 log units) from the limit.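

In this assay, compound 4 gives only a limit, > 10 ug/mL. Placing 8-formyloctyl in place of 1-hydroxynonyl at this position gives an at least 1.2-fold higher number from compound 3 to compound 4 (0.10 log units; that floor lies within the scatter), so the change shows no gain in growth inhibition, though its floor does not establish a loss. The step for hydrogen in place of methoxy on a carbonyl carbon cannot be read because compound 2 and compound 4 both sit at the same limit: the limit of > 10 ug/mL in this assay, at which 2 of the 4 values shown sit.

As far as these compounds go, the true size of the step to compound 4 stays open. So does the effect of a carboxylic acid or an amine at this position.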